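The source may report more compounds than this note shows. Statements on the series, on what has been measured and on what is new or still open speak of the compounds shown alone.

Working notes on the series. The shared core carries an alkyl group on the aromatic nitrogen, and two members of it have been measured. Compound 1 `CCC(CC)n1c(-c2ccc(OCc3c(-c4c(Cl)cccc4Cl)noc3C(C)C)cc2)nc2ccc(C(=O)O)cc21`, with pentan-3-yl, gives 26.5 nM in an assay on isolated protein for agonist activity at Bile acid receptor (Homo sapiens), read by TR-FRET; on this read-out higher numbers stand for an effect only at larger amounts of compound and lower numbers for an effect already at smaller amounts. Compound 2 `CC(C)c1onc(-c2c(Cl)cccc2Cl)c1COc1ccc(-c2nc3ccc(C(=O)O)cc3n2CC(C)(C)C)cc1`, with neopentyl, gives 24.8 nM in this assay; on these two numbers compound 2 stands at the lower of the two, and the step of a 1.1-fold lower number from compound 1 to compound 2 (0.03 log units; within the scatter) is within the scatter. Compound 3 `CCn1c(-c2ccc(OCc3c(-c4c(Cl)cccc4Cl)noc3C(C)C)cc2)nc2ccc(C(=O)O)cc21` is not yet measured; it differs from compound 2 by methyl in place of tert-butyl on a saturated chain carbon bound to an aromatic nitrogen, that is, neopentyl to ethyl. For the measured compounds named here, only one measured step bears on the nitrogen substituent, the exchange of pentan-3-yl for neopentyl, and it was flat, so a move between branched groups cost nothing. Going by the values given here, no measured step covers the shrink to ethyl, so the direction is open. A modest rise in the number is expected for compound 3, with the step of a 2.4-fold higher number from compound 2 to compound 3 (0.38 log units; beyond the scatter). Compound 3 is therefore estimated at 60 nM, within 20 nM to 200 nM.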

Compound 3, half-maximal effective concentration: 19.3 nM
For compound 3 the middle estimate is 3.1-fold (0.49 log units) above the measured one; measured number below the stated range.
By their numbers in this assay, from the lowest: compounds 3, 2 and 1 (each within the scatter of the next).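

For the compounds shown here, the earlier step compared only two branched groups in this assay, whereas methyl in place of tert-butyl gives a 1.3-fold lower number from compound 2 to compound 3 (0.11 log units; within the scatter), extending the flat reading to the unbranched ethyl. Ethyl in place of pentan-3-yl likewise gives a 1.4-fold lower number from compound 1 to compound 3 (0.14 log units; within the scatter). Among compound 1, compound 2 and compound 3, neither branching nor the carbon count of this alkyl group separates the values, and no supporting data account for this flatness.

Going by these compounds, whether the same tolerance extends to a benzyl group, a cyclopropyl ring or a chain ending in an amine or hydroxyl on the aromatic nitrogen remains open. Also open, on these data alone, is whether ethyl and the branched groups stay level when a primary amide replaces the carboxylic acid on the shared core.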